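Aryl sulfanyl diamines: fluoro for methoxy on the pendant ring

A few compounds are considered here, and "the series" means these few. Any claim that something is new, unique, unknown or untested is made for them only; others in the source may bear on it.

Measured so far in a functional assay on SK-MEL-2 cells (Homo sapiens) for inhibition, read by sulforhodamine B assay, with a stated time of 48 h; a lower number here means that less compound is tolerated, a higher number that more compound is tolerated:
compound 1, `CCOC(=O)[C@H](CCC(=O)O)NC(=O)c1ccc(CNc2nc3cc(N)cc(N)c3nc2-c2ccccc2)cc1`: < 100000 nM
compound 2, `COc1ccc(CNc2nc3cc(N)cc(N)c3nc2-c2ccccc2)cc1OC`: < 100000 nM
compound 3, `COc1ccc(Sc2nc3cc(N)cc(N)c3nc2-c2ccccc2)cc1`: < 100000 nM

Within the data shown here, every value in this assay so far is a limit, not a number. Compound 3 sits at the limit of < 100000 nM in this assay, at which 3 of the 3 values shown sit, so its place among the three can only be said to be shared with the other two. Among the measured compounds shown here, no pair of measured compounds differs in a single place, so no measured step is available.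

Compound 4, `Nc1cc(N)c2nc(-c3ccccc3)c(Sc3ccc(F)cc3)nc2c1`, is the next compound; it differs from compound 3 by fluoro in place of methoxy on an aromatic carbon. With nothing measured to anchor the change, no shift beyond the scatter is expected, and the step from compound 3 to compound 4 is estimated as a step that the limit leaves unreadable from compound 3 to compound 4. For compound 4 the expected value in this assay is 30000 nM, within 5000 nM to 100000 nM.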

Compound 4, concentration lethal to 50% of the cells: < 100000 nM
Compound 4 ended at the assay's limit; the forecaster's own chance of this, stated with the estimate: 60%; the middle value lies beyond the limit too.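

The step between compound 3 and compound 4 in this assay cannot be read, because both values are limits, not numbers: the limit of < 100000 nM in this assay, at which 4 of the 4 values shown sit.

The compounds shown leave open what size of shift, if any, fluoro in place of methoxy produces, and how any of the four compares with another.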